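Shortening the Ester from Isopropyl to Ethyl

The source may hold more compounds than are shown below. What is called first, only, known or untested is meant among the compounds shown, and "the series" means these compounds.

Compound 1 `CC1=C(C(=O)OC(C)C)C(C2CCCC2)N/C(=N/C#N)N1`: 3%
Compound 2 `CC1=C(C(=O)OC(C)C)C(c2ccccc2)N/C(=N/C#N)N1`: 6%

In an assay on HeLa cells for displacement of a labelled ligand from adenosine receptor A3 (Homo sapiens), with a stated time of 180 min, tested at 1 uM (on this read-out higher numbers stand for more inhibition at the one concentration tested (going by the name of the read-out) and lower numbers for less inhibition), compound 1 gives 3%, the lowest of the two numbers, while compound 2 gives 6%; the step of a number 3 percentage points higher from compound 1 to compound 2 (within the scatter) lies within the scatter. Compound 3 `CCOC(=O)C1=C(C)N/C(=N\C#N)NC1C1CCCC1` differs from compound 1 by hydrogen in place of methyl on a saturated chain carbon bound to an oxygen next to a carbonyl group and a saturated chain carbon. Among the measured compounds shown here, the single measured step, a number 3 percentage points higher from compound 1 to compound 2 (within the scatter), changes a different part of the shared core and was itself within the scatter, so no measured step speaks directly to this change, and both numbers in this assay are small. Compound 3 is therefore expected to show a number 1 percentage points higher from compound 1 to compound 3 (within the scatter), no step beyond the scatter. Compound 3 is estimated at 4%, between -6% and 14%.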

Compound 3, a percentage reported as inhibition, at one concentration (the size of the read-out at that concentration, not a potency): 4%
For compound 3 middle estimate and measured number coincide at the digits printed, within the range that was stated.
By their numbers in this assay, from the lowest: compounds 1, 3 and 2 (each within the scatter of the next).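

Among the compounds shown here, with compound 3 the ester itself is altered for the first time: in this assay, isopropyl to ethyl gives a number 1 percentage points higher from compound 1 to compound 3 (within the scatter) and so sets the two compounds no measurable distance apart. At this position, then, the isopropyl and ethyl esters cannot be told apart at these low levels of inhibition. No measurement shown explains this result. Still open, going by these compounds, is whether a longer chain on the ester, or a carboxylic acid in its place, would give a clearly different number. Also open, on these data alone, is whether ethyl gives the same picture with phenyl in place of cyclopentyl.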